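This account rests on a few compounds, and the source may have more. Where it says the series, first, only, none or still open, it means among the compounds named here.

Working notes on the series, read in a functional assay on KB cells (Homo sapiens) for antiproliferative activity, read by sulforhodamine B assay, with a stated time of 3 days; on this read-out higher numbers stand for an effect only at larger amounts of compound and lower numbers for an effect already at smaller amounts. Compound 1 `CCC1=C(O)c2c(oc(-c3ccc(O)cc3)cc2=O)C(CC)(CC)C1=O` gives 20.6 uM, compound 2 `CCC1=C(O)c2c(oc(-c3ccc(C)c(Cl)c3)cc2=O)C(CC)(CC)C1=O` gives 39 uM, and compound 3 `CCC1=C(O)c2c(oc(-c3cc(C)cc(C)c3)cc2=O)C(CC)(CC)C1=O` gives 45.5 uM. Among the compounds with values here, compound 3 lies at the high end of these numbers, but only one of its two steps goes beyond the scatter: a 2.2-fold higher number from compound 1 to compound 3 (0.34 log units; beyond the scatter) is modest, while a 1.2-fold higher number from compound 2 to compound 3 (0.07 log units; within the scatter) stays within it.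

Compound 4 `CCC1=C(O)c2c(oc(-c3cc(C)ccc3F)cc2=O)C(CC)(CC)C1=O` changes the group on an aromatic carbon next to the ring oxygen: 2-fluoro-5-methylphenyl in place of 3,5-dimethylphenyl on an aromatic carbon. Within the data shown here, the nearest precedent is the exchange of one substituted phenyl for another in that same place, a 1.2-fold higher number from compound 2 to compound 3 (0.07 log units; within the scatter). The step of a 1.9-fold higher number from compound 1 to compound 2 (0.28 log units; within the scatter) is also within the scatter. Among the measured compounds shown here, no measured step introduces fluorine on this phenyl, so the precedent is indirect. On the evidence of those steps, no change beyond the scatter is expected in this assay, and any drift has no firm direction. The expected step is a 1.1-fold lower number from compound 3 to compound 4 (0.06 log units; within the scatter). The estimated value for compound 4 is 40 uM, with an expected range of 22 uM to 70 uM.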

Compound 4, concentration for half-maximal effect: 47.3 uM
Estimate against measurement, compound 4: 1.2-fold (0.07 log units) below; the range from low to high includes it.
By their numbers in this assay, from the lowest: compounds 1, 2, 3 and 4 (each within the scatter of the next, the first and the last beyond it).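

In this assay, within the data shown here, a fluorine on this phenyl appears for the first time, yet a 1.0-fold higher number from compound 3 to compound 4 (0.02 log units; within the scatter) and a 1.2-fold higher number from compound 2 to compound 4 (0.08 log units; within the scatter) leave 2-fluoro-5-methylphenyl indistinguishable from 3,5-dimethylphenyl and 3-chloro-4-methylphenyl at this place next to the ring oxygen. Among these compounds, only the step from 4-hydroxyphenyl, a 2.3-fold higher number from compound 1 to compound 4 (0.36 log units; beyond the scatter), goes beyond the scatter and is modest, matching the step from compound 1 to compound 3, although the step from compound 1 to compound 2 goes against any clean split by staying within the scatter. Nothing available explains why these groups read alike.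

Still open, on these data alone, is how a phenyl carrying an amine, a carboxylic acid or a longer chain such as butoxy would read at this place. Also open, as far as these compounds go, is what a morpholine or a pyridine ring in place of the phenyl would give.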